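Removing a Methyl from the Core of Compound 1

The source may report more compounds than this note shows. Statements on the series, on what has been measured and on what is new or still open speak of the compounds shown alone.

Compound 1 `C=C1CC(Cn2cc(C)c(=O)[nH]c2=O)(c2ccc(-c3ccccc3)cc2)OC1=O`: in a functional assay on SW-620 cells (Homo sapiens) for inhibition (on this read-out higher numbers stand for weaker inhibition of growth and lower numbers for stronger inhibition of growth), compound 1 gives 1020 nM.
Compound 2 `C=C1CC(Cn2cc(C)c(=O)[nH]c2=O)(c2ccc(F)cc2)OC1=O`: in this assay compound 2 gives 3630 nM.

Compound 1 holds the lowest of the two numbers; its nearest neighbour is compound 2, reached through the step of a 3.6-fold higher number from compound 1 to compound 2 (0.55 log units; beyond the scatter). Compound 3 `C=C1CC(Cn2ccc(=O)[nH]c2=O)(c2ccc(-c3ccccc3)cc2)OC1=O` differs from compound 1 only by hydrogen in place of methyl on an aromatic carbon. Among the measured compounds shown here, no measured step touches this place, and the step from compound 1 to compound 2 does not bear on it; nothing in the data speaks for a shift beyond the scatter. The number for compound 3 is therefore expected to lie near that of compound 1, as the step of a 1.5-fold higher number from compound 1 to compound 3 (0.17 log units; within the scatter). Compound 3 is estimated at 1500 nM, within 500 nM to 5000 nM.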

Compound 3, concentration for 50% growth inhibition: 170 nM
Compound 3: the middle estimate sits 8.8-fold (0.95 log units) above what was measured; the measured number lies below the stated range.
By their numbers in this assay, from the lowest: compound 3; then compound 1; then compound 2.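

In this assay, hydrogen in place of methyl on this aromatic carbon gives a 6.0-fold lower number from compound 1 to compound 3 (0.78 log units; beyond the scatter), a change beyond the scatter. Among the compounds shown here, the earlier step concerned only fluoro in place of phenyl, so this result is the first to show that the number also responds at this position of the core, with the methyl not needed for inhibition of growth. Nothing available explains this shift.

Going by these compounds, whether the same change would hold alongside fluoro in place of phenyl remains open. So does what an ethyl group or an amine on this aromatic carbon would give.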